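Trading a diol chain for a tetramethylpiperidinyl ether

The source may report more compounds than this note shows. Statements on the series, on what has been measured and on what is new or still open speak of the compounds shown alone.

Three compounds have numbers in an assay for inhibition of serine/threonine-protein kinase Sgk1 (Homo sapiens), with stated times of 30 min and 60 min, in the presence of a further agent that is not named here; a lower number here means a stronger inhibitor, a higher number a weaker inhibitor. Compound 1 `CN1CCC(NC(=O)c2cc(-c3ccc(NS(=O)(=O)c4cccc(Cl)c4Cl)cc3)nc3[nH]ncc23)C1` gives 21 nM, and compound 2 `O=C(NC1CCN(CC2CC2)C1)c1cc(-c2ccc(NS(=O)(=O)c3cccc(Cl)c3Cl)cc2)nc2[nH]ncc12` gives 35 nM; the step of a 1.7-fold higher number from compound 1 to compound 2 (0.22 log units; within the scatter) lies within the scatter. Compound 3 `Cc1n[nH]c2nc(-c3ccc(NS(=O)(=O)c4cc(Cl)ccc4F)cc3)nc(OCC(CO)CO)c12` gives 2 nM, the lowest number of the three, with compound 1 the nearest and compound 2 the furthest, both gaps beyond the scatter. Compound 4 `Cc1n[nH]c2nc(-c3ccc(NS(=O)(=O)c4cc(Cl)ccc4F)cc3)nc(OC3CC(C)(C)NC(C)(C)C3)c12` has not yet been measured in this assay. It differs from compound 3 in one place: 2,2,6,6-tetramethylpiperidin-4-yl in place of 3-hydroxy-2-(hydroxymethyl)propyl on an oxygen on an aromatic ring. Among the compounds with values here, none of the measured steps touches this part of the molecule or this kind of exchange; the only measured step, from compound 1 to compound 2, concerns a different scaffold and a different group and was within the scatter, so it offers no direct guide. Without a bearing step, compound 4 is expected to remain close to compound 3, with the step of a 2.0-fold higher number from compound 3 to compound 4 (0.30 log units; within the scatter) estimated as small and of uncertain direction. Compound 4 is therefore estimated at 4 nM, within a range from 1 nM to 20 nM.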

Compound 4, half-maximal inhibitory concentration: 4 nM
Compound 4: the middle estimate sits on the measured number at the digits printed; low and high end bracket the measured number.
By their numbers in this assay, from the lowest: compounds 3 and 4 (each within the scatter of the next); then compounds 1 and 2 (each within the scatter of the next).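

In this assay, the exchange on an oxygen on an aromatic ring gives a 2.0-fold higher number from compound 3 to compound 4 (0.30 log units; within the scatter). At this position, then, an open chain of 6 heavy atoms with 2 hydrogen-bond donors and a six-membered ring of 10 heavy atoms with 1 hydrogen-bond donor cannot be told apart, so the inhibition seen with compound 3 does not depend on keeping 3-hydroxy-2-(hydroxymethyl)propyl there. No measured evidence accounts for this result.

The compounds shown leave open whether this oxygen would accept a group such as a carboxylic acid, a longer chain or an unsubstituted piperidin-4-yl ring. Within the data shown here, this exchange is also seen on only one core, so whether it would hold on the core of compound 1 remains unknown.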